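The compounds below may be only part of what the source reports. "The series", "measured", "known", "first", "only" and "open" are said of these compounds alone.

Working notes on the esters of the shared core, read in an ADME assay on MRC5 cells (Homo sapiens) for cytotoxicity, read by neutral red uptake, with a stated time of 24 h; a lower number here means a stronger inhibitor, a higher number a weaker inhibitor. For the measured compounds named here, compound 1 `CC(C)C(=O)Oc1c(C(C)C)cc2c3c1OC(=O)[C@@]31CCCC(C)(C)[C@@H]1CC2` gives 119000 nM, the lower of the two numeric values so far. Compound 3 `CCCCC/C=C/C/C=C/CCCCCCCC(=O)Oc1c(C(C)C)cc2c3c1OC(=O)[C@@]31CCCC(C)(C)[C@@H]1CC2` gives 293000 nM, a higher number that stands apart from compound 1 by more than the scatter. Compound 2 `CCCCCCCCCCCCCCCC(=O)Oc1c(C(C)C)cc2c3c1OC(=O)[C@@]31CCCC(C)(C)[C@@H]1CC2` reads > 1000000 nM, which is a limit of the assay and not a number.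

The next compound is compound 4 `CC(C)c1cc2c3c(c1OC(=O)c1cccnc1)OC(=O)[C@@]31CCCC(C)(C)[C@@H]1CC2`, and its change from compound 1 is pyridin-3-yl in place of isopropyl on a carbonyl carbon. Going by the values given here, only one measured step is available, an at least 3.4-fold lower number from compound 2 to compound 3 (0.53 log units; beyond the scatter), with deca-1,4-dien-1-yl in place of octyl on a saturated chain carbon. That step is open-ended and stays within the long chains, so it bears only loosely on this change. Among the compounds with values here, no measured step places a ring on this carbonyl carbon. The best anchor is therefore compound 1 at 119000 nM, with uncertainty widened by the size of the measured step of an at least 3.4-fold lower number from compound 2 to compound 3 (0.53 log units; beyond the scatter). The expected change is a 1.1-fold higher number from compound 1 to compound 4 (0.04 log units; within the scatter), an estimate with no clear direction beyond the scatter. For compound 4 the estimated value is 130000 nM, with an expected range of 45000 nM to 400000 nM.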

Compound 4, half-maximal inhibitory concentration: 296000 nM
Compound 4: the middle estimate sits 2.3-fold (0.36 log units) below what was measured; the measured number falls inside the stated range.
By their numbers in this assay, from the lowest: compound 1; then compounds 3 and 4 (each within the scatter of the next). At a limit, above all of these: compound 2.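

In this assay, for the compounds shown here, the carbonyl carbon of the ester carries a ring for the first time, and the change of pyridin-3-yl for isopropyl gives a 2.5-fold higher number from compound 1 to compound 4 (0.40 log units; beyond the scatter). This adds to the earlier picture, which rested on a single step within the long chains, by showing that the group on this carbonyl carbon also moves the number when the group is short and when it holds a six-membered aromatic ring with one hetero atom; the step is modest, yet it lies beyond the scatter. Compound 2 remains a limit and not a number, the only such reading among the compounds shown: the limit of > 1000000 nM in this assay, at which 1 of the 4 values shown sits.

On these data alone, whether this step follows from the ring as such or from its nitrogen stays open, as a single pyridin-3-yl ester cannot separate the two and a phenyl group on the same carbonyl carbon would be needed to do so. Also open, as far as these compounds go, is how this carbonyl carbon responds to a small methyl group, or to a short chain ending in an amine or a carboxylic acid.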